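A Fluorine for a Methoxy Group at the Chain End

The source may hold more compounds than are shown below. What is called first, only, known or untested is meant among the compounds shown, and "the series" means these compounds.

Compound 1 `COc1ccc(/C=C/C(=O)Nc2cc(C(=O)c3cc(OC)c(OC)c(OC)c3)cc(OC)c2OC)cc1`: in a functional assay on HeLa cells (Homo sapiens) for cytotoxicity, read by MTT assay, with a stated time of 72 h (a lower number here means a stronger inhibitor, a higher number a weaker inhibitor), compound 1 gives 11200 nM
Compound 2 `COc1cccc(/C=C/C(=O)Nc2cc(C(=O)c3cc(OC)c(OC)c(OC)c3)cc(OC)c2OC)c1`: in this assay compound 2 gives 6900 nM

Going by the values given here, of the two measured compounds, compound 2 holds the lower number, but the only step measured, a 1.6-fold lower number from compound 1 to compound 2 (0.21 log units; within the scatter), lies within the scatter, so compound 2 and compound 1 cannot be told apart on these data. Compound 3 `COc1cc(C(=O)c2cc(OC)c(OC)c(OC)c2)cc(NC(=O)/C=C/c2ccc(F)cc2)c1OC` differs from compound 2 in one place: 4-fluorophenyl in place of 3-methoxyphenyl on a double-bonded chain carbon bound to a double-bonded chain carbon. Among the compounds with values here, no measured step bears directly on this change, since the single step on record moves a methoxy group from one ring position to another rather than replacing it with fluorine. That step was small, and nothing in the two numbers suggests that the substituent on this ring drives large shifts in this assay. Compound 3 is therefore expected to stay close to compound 2, with a step of a 1.2-fold higher number from compound 2 to compound 3 (0.06 log units; within the scatter) that is not expected to exceed the scatter. Compound 3 is estimated at 8000 nM, within a range from 2500 nM to 25000 nM, the width reflecting how little the measured compounds say about a methoxy-to-fluorine exchange.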

Compound 3, half-maximal inhibitory concentration: 900 nM
The estimate for compound 3 lay 8.9-fold (0.95 log units) above the measured number; the measured number lies below the stated range.
By their numbers in this assay, from the lowest: compound 3; then compounds 2 and 1 (each within the scatter of the next).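

In this assay, the ring at the chain end turns out to matter: a 7.7-fold lower number from compound 2 to compound 3 (0.88 log units; beyond the scatter), with 4-fluorophenyl in place of 3-methoxyphenyl, whereas the two methoxy compounds alone had shown no difference beyond the scatter. The exchange is seen in its simplest form in the step with fluoro in place of methoxy on an aromatic carbon, a 12-fold lower number from compound 1 to compound 3 (1.09 log units; beyond the scatter), and this step too lies beyond the scatter, so the lower number of compound 3 does not depend on which methoxy compound serves as the reference. What the earlier pair could not show is now plain: at this position, a change of substituent can move the number well beyond the scatter, although no evidence is available to explain this shift.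

The compounds shown leave open whether this drop belongs to fluoro in particular or would also follow from chloro, a hydroxyl group or an amine on the same ring. They also leave open whether the unsubstituted phenyl ring would give a number closer to that of compound 3 or to those of the methoxy compounds.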